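Methoxy for fluoro on two related flavonoid oxime ethers

A few compounds are considered here, and "the series" means these few. Any claim that something is new, unique, unknown or untested is made for them only; others in the source may bear on it.

Measured compounds:
Compound 1, `O=c1cc(-c2ccccc2)oc2ccc(OC/C(=N/O)c3ccc(F)cc3)cc12`, 2800000 nM
Compound 2, `COc1ccc(/C(COc2ccc3oc(-c4ccccc4)cc(=O)c3c2)=N\O)cc1`, 800000 nM
Compound 3, `O=c1c(-c2ccccc2)coc2cc(OC/C(=N/O)c3ccc(F)cc3)ccc12`, 6610000 nM

The three compounds were tested in a functional assay on SK-HEP1 cells (Homo sapiens) for antiproliferative activity; on this read-out lower numbers stand for stronger inhibition of growth and higher numbers for weaker inhibition of growth. Compound 1 and compound 3 are built from the same atoms joined differently; the difference between their two cores is not broken down here. In this assay compound 3 gives 6610000 nM, the highest of the three numbers, and compound 1 gives 2800000 nM.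

Compound 1 and compound 2 differ by methoxy in place of fluoro on an aromatic carbon, and this change brought a 3.5-fold lower number from compound 1 to compound 2 (0.54 log units; beyond the scatter).

Compound 4, `COc1ccc(/C(COc2ccc3c(=O)c(-c4ccccc4)coc3c2)=N\O)cc1`, is not yet measured. It differs from compound 3 by methoxy in place of fluoro on an aromatic carbon, the same change as that from compound 1 to compound 2, placed in the same words on both cores. Because compound 3 gives 6610000 nM and the earlier step gave a 3.5-fold lower number from compound 1 to compound 2 (0.54 log units; beyond the scatter), a step of similar size is expected, a 3.3-fold lower number from compound 3 to compound 4 (0.52 log units; beyond the scatter). Compound 4 is therefore estimated at 2000000 nM, expected to lie between 800000 nM and 5000000 nM.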

Compound 4, concentration for 50% growth inhibition: 5510000 nM
For compound 4 the middle estimate is 2.8-fold (0.44 log units) below the measured one; measured number outside the range, above it.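

Carried onto the second core, the change from 4-fluorophenyl to 4-methoxyphenyl gave in this assay a 1.2-fold lower number from compound 3 to compound 4 (0.08 log units; within the scatter). The step seen on the core of compound 1 therefore did not carry over in size to the core of compound 3: the same change on two cores in this assay, a 3.5-fold lower number (0.54 log units; beyond the scatter) from compound 1 to compound 2 and a 1.2-fold lower number (0.08 log units; within the scatter) from compound 3 to compound 4, 2.9-fold (0.47 log units) apart, beyond the scatter of two such steps. This shows that, across these two pairs, the outcome of the same swap differs with the core, but two pairs cannot show how the core brings this about or how the swap would fare on any further core.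

The compounds shown leave open how an amine, a carboxylic acid or a chloro group on the same aromatic carbon would behave on either core. They also leave open whether a longer chain than methoxy, such as ethoxy or propoxy, would separate the two cores in the same way.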